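Substituent swaps on the shared core: working notes

A few compounds are considered here, and "the series" means these few. Any claim that something is new, unique, unknown or untested is made for them only; others in the source may bear on it.

Compound 1 `COc1ccccc1-c1cn(C[C@H](O)[C@H]2OC(=O)C(OCc3ccccc3)=C2OCc2ccccc2)nn1`: in a functional assay on HeLa cells (Homo sapiens) for antiproliferative activity, read by MTT assay, with a stated time of 72 h (on this read-out lower numbers stand for stronger inhibition and higher numbers for weaker inhibition), compound 1 reports only a limit, > 100000 nM.
Compound 2 `CC(C)(C)c1cn(C[C@H](O)[C@H]2OC(=O)C(OCc3ccccc3)=C2OCc2ccccc2)nn1`: 18300 nM.
Compound 3 `O=C1O[C@H]([C@@H](O)Cn2cc(CCCCl)nn2)C(OCc2ccccc2)=C1OCc1ccccc1`: 36700 nM.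

Compound 3 holds the highest of the two numbers, with compound 2 close to it: a 2.0-fold higher number from compound 2 to compound 3 (0.30 log units; within the scatter). The limit of compound 1 sits at the top of the set (the limit of > 100000 nM in this assay, at which 1 of the 3 values shown sits). Compound 4 `Cc1ccc(S(=O)(=O)NCc2cn(C[C@H](O)[C@H]3OC(=O)C(OCc4ccccc4)=C3OCc3ccccc3)nn2)cc1` carries ((4-methylphenyl)sulfonyl)amino in place of 2-chloroethyl on a saturated chain carbon bound to an aromatic carbon. Within the data shown here, no measured step touches this chain carbon. The steps on the aromatic carbon, an at least 5.4-fold lower number from compound 1 to compound 2 (0.73 log units; beyond the scatter) and an at least 2.7-fold lower number from compound 1 to compound 3 (0.43 log units; beyond the scatter), both lowered the number when the 2-methoxyphenyl gave way to a non-aromatic group; compound 4 brings a new aromatic ring back, further out, together with the ((4-methylphenyl)sulfonyl)amino group. A step no larger than those seen is expected, a 1.2-fold higher number from compound 3 to compound 4 (0.09 log units; within the scatter), leaning toward a higher number. Compound 4 is estimated at 45000 nM in this assay, between 12000 nM and 150000 nM.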

Compound 4, half-maximal inhibitory concentration: 14400 nM
Beside the measured number, compound 4's estimate is 3.1-fold (0.49 log units) above it; the range from low to high includes it.
By their numbers in this assay, from the lowest: compounds 4, 2 and 3 (each within the scatter of the next, the first and the last beyond it). At a limit, above all of these: compound 1.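

On the saturated chain carbon bound to an aromatic carbon, the first measured change gives a 2.5-fold lower number from compound 3 to compound 4 (0.41 log units; beyond the scatter) in this assay, so the ((4-methylphenyl)sulfonyl)amino group, aromatic ring included, is accepted at this place. The comparison with tert-butyl gives only a 1.3-fold lower number from compound 2 to compound 4 (0.10 log units; within the scatter), which sets no order between those two. An aromatic ring in the substituent does not by itself bring back the number of compound 1, as an at least 6.9-fold lower number from compound 1 to compound 4 (0.84 log units; beyond the scatter) shows, and that step rests on a limit: the limit of > 100000 nM in this assay, at which 1 of the 4 values shown sits.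

Still open, on these data alone, is whether the lower number belongs to the sulfonyl amino link or to the 4-methylphenyl ring. A free amine or a carboxylic acid on the same chain carbon would help to separate the two.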